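A few compounds are considered here, and "the series" means these few. Any claim that something is new, unique, unknown or untested is made for them only; others in the source may bear on it.

Compound 2, with the structure `CC(C)(N)CC(=O)N[C@@H]1CCc2ccccc2N(Cc2ccc(-c3ccccc3-c3nn[nH]n3)cc2)C1=O`, gives 0.06 uM in a functional assay on cells (Pituitary gland cell) with growth hormone secretagogue receptor type 1 (Rattus norvegicus) as the target (on this read-out higher numbers stand for an effect only at larger amounts of compound and lower numbers for an effect already at smaller amounts), the lower of the two numbers seen so far. Compound 1, `CC(C)(CC(=O)N[C@@H]1CCc2ccccc2N(Cc2ccc(-c3ccccc3-c3nn[nH]n3)cc2)C1=O)NCCN`, gives 230 uM in this assay, and the change recorded between them, a 3800-fold lower number from compound 1 to compound 2 (3.58 log units; beyond the scatter), concerns the substituent on the amine nitrogen ( hydrogen in place of 2-aminoethyl ), not the length of the chain carrying that amine. Compound 3, `CC(C)(N)C(=O)N[C@@H]1CCc2ccccc2N(Cc2ccc(-c3ccccc3-c3nn[nH]n3)cc2)C1=O`, differs from compound 2 by 1-amino-1-methylethyl in place of 2-amino-2-methylpropyl on a carbonyl carbon, so the amine is drawn one bond closer to the carbonyl. For the measured compounds named here, no measured step covers this shortening, so the direction can only be guessed; a moderate step of a 5.0-fold higher number from compound 2 to compound 3 (0.70 log units; beyond the scatter) toward a higher number is expected, on the reasoning that compound 2 already sits lowest at 0.06 uM and the free amine was the feature that mattered. For compound 3 the expected value in this assay is 0.3 uM, with a range from 0.05 uM to 2 uM.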

Compound 3, concentration for half-maximal effect in the growth hormone secretagogue receptor type 1 assay: 0.03 uM
For compound 3 the middle estimate is 10-fold (1.00 log units) above the measured one; measured number below the stated range.
By their numbers in the growth hormone secretagogue receptor type 1 assay, from the lowest: compounds 3 and 2 (each within the scatter of the next); then compound 1.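

In the growth hormone secretagogue receptor type 1 assay, replacing 2-amino-2-methylpropyl with 1-amino-1-methylethyl on a carbonyl carbon gives a 2.0-fold lower number from compound 2 to compound 3 (0.30 log units; within the scatter), so at this position the amine can be drawn one bond closer to the carbonyl with no readable change. Carrying 2-aminoethyl on the amine nitrogen remains the change that counts, as the listed step shows: a 7700-fold lower number from compound 1 to compound 3 (3.88 log units; beyond the scatter). The shortening that leaves this read-out within the scatter nevertheless registers clearly in a physicochemical assay for acid dissociation: the measured acid dissociation constant of compound 2, 9.3, and of compound 3, 7.9, a number 1.40 log units lower (beyond the scatter)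

In the physicochemical assay compound 2 gives 9.3 and compound 3 gives 7.9 on this scale. The compounds shown leave open whether a longer chain carrying the amine, or a carboxylic acid in place of that amine, would keep the number in the growth hormone secretagogue receptor type 1 assay. They also leave open whether a single methyl on the amine nitrogen would behave like hydrogen or like 2-aminoethyl.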